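Swapping trifluoromethyl for methoxy on the anilino ring

A few compounds are considered here, and "the series" means these few. Any claim that something is new, unique, unknown or untested is made for them only; others in the source may bear on it.

Compound 1, `COc1ccc(N/C=C\C(=O)c2cn(-c3ccccc3)nc2-c2ccccc2)cc1`: in a functional assay on A549 cells (Homo sapiens) for antiproliferative activity, read by MTT assay, with a stated time of 48 h (a higher number here means a weaker inhibitor, a lower number a stronger inhibitor), compound 1 gives 3250 nM.
Compound 2, `COc1cc(-c2nn(-c3ccccc3)cc2C(=O)/C=C\Nc2ccc(C(F)(F)F)cc2)cc(OC)c1OC`: in this assay compound 2 gives only > 50000 nM, which is a limit of the assay and not a number.

Of the two values shown, compound 2 sits at the weak end, on the limit itself (the limit of > 50000 nM in this assay, at which 1 of the 2 values shown sits). Among the compounds with values here, compound 1, which differs from compound 2 in more than one place, gives a measured number, so the two values show only that compound 1 inhibits growth where compound 2 does not within the range of this assay.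

Compound 3, `COc1ccc(N/C=C\C(=O)c2cn(-c3ccccc3)nc2-c2cc(OC)c(OC)c(OC)c2)cc1`, is compound 2 with one change: methoxy in place of trifluoromethyl on an aromatic carbon, para to a large group. Within the data shown here, no measured pair shows this exact change, so the size of the step is open. Compound 3 shares its methoxyphenylamino part with compound 1, which gives 3250 nM, so some gain over compound 2 is expected, toward the measured range, though the shared trimethoxyphenyl of compound 2 may hold it back. The expected step is an at least 3.3-fold lower number from compound 2 to compound 3 (0.52 log units; beyond the scatter). Compound 3 is estimated at 15000 nM, between 3000 nM and 50000 nM.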

Compound 3, half-maximal inhibitory concentration: 4780 nM
Compound 3: middle estimate off by 3.1-fold (0.50 log units), on the high side; the measured number falls inside the stated range.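

In this assay, methoxy in place of trifluoromethyl on the aromatic ring of the anilino part gives an at least 10-fold lower number from compound 2 to compound 3 (1.01 log units; beyond the scatter), so among these compounds this one place separates a measurable effect on cell growth from none within the range of the assay. Compound 2 stands on a limit of the assay and not on a number, so the step has a known minimum but no known full size: the limit of > 50000 nM in this assay, at which 1 of the 3 values shown sits. With the (4-methoxyphenyl)amino part in place, 3,4,5-trimethoxyphenyl in place of phenyl gives a 1.5-fold higher number from compound 1 to compound 3 (0.17 log units; within the scatter), so that second change shows no difference that can be told from the scatter.

Only two groups are shown at the anilino position, so it remains open whether methoxy itself matters or whether a hydroxyl, an amine or a chlorine would serve as well. Within the data shown here, also open is whether the same swap would have a similar effect on a compound carrying plain phenyl rather than 3,4,5-trimethoxyphenyl, since the one measured step with this swap has the trimethoxyphenyl group in place.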